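The source may report more compounds than this note shows. Statements on the series, on what has been measured and on what is new or still open speak of the compounds shown alone.

In a functional assay on DU-145 cells (Homo sapiens) for inhibition, read by WST assay, with a stated time of 3 days (a higher number here means a weaker inhibitor, a lower number a stronger inhibitor), compound 1 `CCCCn1ccnc1/C=C/C(=O)/C=C/c1coc2ccccc2c1=O` gives 4300 nM and compound 2 `CCC(C)n1ccnc1/C=C/C(=O)/C=C/c1coc2ccccc2c1=O` gives 3300 nM, so compound 2 stands level with compound 1 within the usual scatter. Compound 3 `CCCC(C)n1ccnc1/C=C/C(=O)/C=C/c1coc2ccccc2c1=O` is unmeasured and differs from compound 2 by methyl in place of hydrogen on a saturated chain carbon, three bonds along the chain from an aromatic nitrogen. Among the compounds with values here, the one measured step that bears on this also alters that chain, and it is small: a 1.3-fold lower number from compound 1 to compound 2 (0.11 log units; within the scatter). No shift beyond the scatter is therefore expected, and the expected step is no change at the digits printed from compound 2 to compound 3 (within the scatter). The estimate for compound 3 is 3300 nM, with a range of 1500 nM to 7000 nM.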

Compound 3, half-maximal inhibitory concentration: 1400 nM
Compound 3: middle estimate off by 2.4-fold (0.37 log units), on the high side; the whole stated range lies above it.
By their numbers in this assay, from the lowest: compound 3; then compounds 2 and 1 (each within the scatter of the next).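

In this assay, the methyl that turns sec-butyl into 1-methylbutyl gives a 2.4-fold lower number from compound 2 to compound 3 (0.37 log units; beyond the scatter), so a change this small in the group on the aromatic nitrogen can move the number beyond the scatter. Placing the methyl instead on the chain carbon bound to that nitrogen, with the butyl chain kept, gives a 3.1-fold lower number from compound 1 to compound 3 (0.49 log units; beyond the scatter). The earlier step, a 1.3-fold lower number from compound 1 to compound 2 (0.11 log units; within the scatter), showed no such shift. On these data alone, whether a longer branched chain or a chain ending in an amine would lower the number further stays open. What lies behind the shift also stays open, as no measurement shown explains it.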